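Inverting the ring stereocentre of compound 1

This account rests on a few compounds, and the source may have more. Where it says the series, first, only, none or still open, it means among the compounds named here.

compound 1 `CN1CCN(c2ccc(Nc3ncc4nc(Nc5ccc(F)cc5)n([C@H]5CCCNC5)c4n3)cc2)CC1`: 38 nM
compound 2 `CN1CCN(c2ccc(Nc3ncc4nc(Nc5ccccc5)n([C@H]5CCN(C(=O)OC(C)(C)C)C5)c4n3)cc2)CC1`: 110 nM
compound 3 `CN1CCN(c2ccc(Nc3ncc4nc(Nc5ccccc5)n([C@H]5CCNC5)c4n3)cc2)CC1`: 530 nM

In a functional assay on HCC827 cells (Homo sapiens) for antiproliferative activity, read by MTT assay, with a stated time of 72 h (a higher number here means a weaker inhibitor, a lower number a stronger inhibitor), compound 1 holds the lowest of the three numbers, and compound 2 and compound 3 both lie beyond the scatter above it. Compound 4 `CN1CCN(c2ccc(Nc3ncc4nc(Nc5ccc(F)cc5)n([C@@H]5CCCNC5)c4n3)cc2)CC1` is still unmeasured. Its difference from compound 1 is the two compounds have the same atoms and bonds and differ only in configuration as drawn: 1 of 1 stereo elements differ; a stereocentre at a saturated ring carbon is drawn S in compound 1 and R in compound 4: a stereocentre at a saturated ring carbon is drawn S in compound 1 and R in compound 4.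

Going by the values given here, no measured pair differs in configuration alone. Among the compounds with values here, the one measured step, a 4.8-fold higher number from compound 2 to compound 3 (0.68 log units; beyond the scatter), puts hydrogen in place of tert-butoxycarbonyl on an amine nitrogen in a ring, so it offers only a rough scale and no direct precedent. Compound 1 already stands at the low end with 38 nM, so a move to a higher number in this assay is expected, probably smaller than that measured step, although a result within the scatter remains possible. The expected change is a 2.4-fold higher number from compound 1 to compound 4 (0.37 log units; beyond the scatter). Compound 4 is estimated at 90 nM, with an expected range of 25 nM to 350 nM.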

Compound 4, half-maximal inhibitory concentration: 120 nM
Estimate against measurement, compound 4: 1.3-fold (0.12 log units) below, within the range that was stated.
By their numbers in this assay, from the lowest: compound 1; then compounds 2 and 4 (each within the scatter of the next); then compound 3.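

The ring stereocentre matters at this position: in this assay the step is a 3.2-fold higher number from compound 1 to compound 4 (0.50 log units; beyond the scatter), so the configuration drawn S gives the lower number and the configuration drawn R the higher one. The gap can be assigned to this centre alone because nothing else in the structure changes: the fact that compounds 1 and 4 differ only in the configuration as drawn. Inversion weakens the compound without abolishing its activity, as compound 4 still gives 120 nM.

As far as these compounds go, it remains open whether inversion moves the number in the same direction of compound 2 and compound 3, where the ring differs from that of compound 1. Also open, from the compounds shown here alone, is whether a methyl or acetyl group on the amine nitrogen in the ring would preserve the gap between the two configurations.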